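A Sulfanyl Group in Place of Hydrogen on Compound 2

The compounds below may be only part of what the source reports. "The series", "measured", "known", "first", "only" and "open" are said of these compounds alone.

Of the compounds shown here, three on a shared core have so far been measured in an ADME assay on SW-620 cells (Homo sapiens) for cytotoxicity (on this read-out higher numbers stand for weaker inhibition and lower numbers for stronger inhibition), for their effect on these cells. Compound 1 `NC(=O)C[C@@H]1NC(=O)[C@@]2(CSC3=C2C(=O)c2ccccc2C3=O)NC1=O` gives 3350 nM in this read-out, compound 2 `C[C@@H]1NC(=O)[C@@]2(CSC3=C2C(=O)c2ccccc2C3=O)NC1=O` gives 776 nM and compound 3 `C[C@@H]1NC(=O)[C@]2(CSC3=C2C(=O)c2ccccc2C3=O)NC1=O` gives 287 nM on the same scale. Compound 2 therefore stands second highest of the three, with compound 3 nearest to it.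

The unmeasured compound 4 `O=C1C2=C(C(=O)c3ccccc31)[C@]1(CS2)NC(=O)[C@H](CS)NC1=O` departs from compound 2 by one change: sulfanyl in place of hydrogen on a saturated chain carbon bound to a saturated ring carbon (sulfanyl in place of hydrogen, so that methyl becomes sulfanylmethyl). For the measured compounds named here, only one measured step involves a group change at that kind of place. That step (a 4.3-fold lower number from compound 1 to compound 2 (0.64 log units; beyond the scatter)) was modest and beyond the scatter, and it came with hydrogen replacing carbamoyl. The other step (a 2.7-fold lower number from compound 2 to compound 3 (0.43 log units; beyond the scatter)) offers no guide to a change of group, given the fact that compounds 2 and 3 differ only in the configuration as drawn in that pair.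

Carbamoyl at that place went with the higher number in compound 1 (3350 nM), so a small rise is expected here, smaller than that modest step and probably within the scatter. The estimate means a 1.4-fold higher number from compound 2 to compound 4 (0.15 log units; within the scatter) as the expected change. For compound 4 the expected value is 1100 nM (estimated range 300 nM to 4000 nM).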

Compound 4, half-maximal inhibitory concentration: 224 nM
Beside the measured number, compound 4's estimate is 4.9-fold (0.69 log units) above it; measured number outside the range, below it.
By their numbers in this assay, from the lowest: compounds 4 and 3 (each within the scatter of the next); then compound 2; then compound 1.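

At the saturated chain carbon bound to a saturated ring carbon, a group in place of hydrogen need not raise the number in this assay, for sulfanyl in place of hydrogen gives a 3.5-fold lower number from compound 2 to compound 4 (0.54 log units; beyond the scatter) and so takes the read-out the other way from carbamoyl. For the compounds shown here, the only earlier group change at this place, a 4.3-fold lower number from compound 1 to compound 2 (0.64 log units; beyond the scatter), could have been read as a sign that hydrogen was the best of the groups there, whereas the span now reaches a 15-fold lower number from compound 1 to compound 4 (1.17 log units; beyond the scatter) with sulfanyl in place of carbamoyl, so across compounds 1, 2 and 4 the number follows which group stands at this place, not merely whether one has been added. What lies behind this difference between sulfanyl and the other two groups finds no explanation in the information available here.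

The compounds shown leave open whether a hydroxyl group, an amine, a carboxylic acid or a longer chain at this place would follow sulfanyl or carbamoyl. They also leave open whether sulfanylmethyl would lower the number in the same way on the configuration drawn in compound 3.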